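Benzyl in place of cyano: compound 4 from compound 3

This account rests on a few compounds, and the source may have more. Where it says the series, first, only, none or still open, it means among the compounds named here.

Measured so far in a functional assay on aorta for antagonist activity at Alpha-1D adrenergic receptor (Rattus norvegicus); a lower number here means tighter binding, a higher number weaker binding:
compound 1, `COc1ccccc1N1CCN(CCCNc2ncc(C#N)cc2C(=O)N(C)C)CC1`, gives 20 nM
compound 2, `COc1ccccc1N1CCN(CCCNc2nc(C)cc(C)c2C(N)=O)CC1`, gives 39.8 nM
compound 3, `CN(C)C(=O)c1cccnc1NCCCN1CCN(c2ccccc2C#N)CC1`, gives 10 nM

Compound 3 has the lowest of the three numbers in this assay; compound 1 sits within the scatter of it, so no order between those two is claimed, while compound 2 stands beyond the scatter at the weaker end. Compound 4, `CN(C)C(=O)c1cccnc1NCCCN1CCN(c2ccccc2Cc2ccccc2)CC1`, differs from compound 3 in one place: benzyl in place of cyano on an aromatic carbon. Among the compounds with values here, no measured pair shows this kind of change, so its size cannot be read from the series. A moderate weakening is expected for compound 4, close to the edge of the scatter, a 2.5-fold higher number from compound 3 to compound 4 (0.40 log units; beyond the scatter). Compound 4 is estimated at 25 nM, in the range 8 nM to 80 nM.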

Compound 4, dissociation constant: 79.4 nM
Compound 4: middle estimate off by 3.2-fold (0.50 log units), on the low side, within the range that was stated.
By their numbers in this assay, from the lowest: compounds 3, 1, 2 and 4 (each within the scatter of the next, the first and the last beyond it).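

In this assay, benzyl in place of cyano on this aromatic carbon, ortho to a large group, gives a 7.9-fold higher number from compound 3 to compound 4 (0.90 log units; beyond the scatter). Within the data shown here, this is the first single-place step, and it shows that the group held here can move the number beyond the scatter, with the exchange of cyano for benzyl going towards weaker binding. Nothing available explains this loss.

With a single step at this place, size and ring content cannot be separated. On these data alone, whether a chloro or a phenyl group here would fall nearer compound 3 or compound 4 stays open.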